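This account rests on a few compounds, and the source may have more. Where it says the series, first, only, none or still open, it means among the compounds named here.

Compound 3 `CCOc1ccc(COc2c(OC)cc(/C=C/C(=O)OCC(=O)Nc3ccc(Cl)cc3)cc2OC)cc1` stands only at a limit of a functional assay on K562 cells (Homo sapiens) for cytotoxicity, read by MTT assay, with a stated time of 72 h; on this read-out lower numbers stand for stronger inhibition and higher numbers for weaker inhibition: in this assay compound 3 gives > 200000 nM, a limit and not a number. Compound 1 `COc1ccc(/C=C/C(=O)OCC(=O)Nc2ccccc2)cc1OC` likewise gives only a limit in this assay, > 200000 nM. Within the data shown here, compound 2 `COCOc1cc(/C=C/C(=O)OCC(=O)NCc2ccco2)ccc1OCc1ccccc1` is the one that gives a number, 300 nM in this assay. Two of the three results thus sit at the same limit (the limit of > 200000 nM in this assay, at which 2 of the 3 values shown sit). Compound 4 `CCOc1ccc(COc2c(OC)cc(/C=C/C(=O)OCC(=O)Nc3ccccc3)cc2OC)cc1` differs from compound 3 by a single change, (hydrogen in place of chloro on an aromatic carbon). Among the measured compounds shown here, no step between measured compounds is at hand to size this change. Compound 1 also bears the phenylcarbamoyl group and sits only at a limit. The expected step is therefore none beyond the scatter, a step that the limit leaves unreadable from compound 3 to compound 4. Compound 4 is estimated at 300000 nM in this assay, within 50000 nM to 2000000 nM, most likely reported again only as a limit.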

Compound 4, half-maximal inhibitory concentration: > 200000 nM
Compound 4 gave a limit, no number; the forecaster's own chance of this, stated with the estimate: 85%; the middle value lies beyond the limit too.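

Compound 3 and compound 4 each stand only at a limit, so no step can be read between them: the limit of > 200000 nM in this assay, at which 3 of the 4 values shown sit.

The compounds shown leave open whether hydrogen in place of chloro on this aromatic carbon changes cytotoxicity at all.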